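A few compounds are considered here, and "the series" means these few. Any claim that something is new, unique, unknown or untested is made for them only; others in the source may bear on it.

Measured in a functional assay on the whole organism with Mus musculus as the target; on this read-out lower numbers stand for an effect already at smaller amounts and higher numbers for an effect only at larger amounts of compound:
- compound 1 `CCn1c(=O)[nH]c2c(ncn2C2O[C@H](CO)[C@@H](O)[C@H]2O)c1=N`: > 100 mg/kg
- compound 2 `CCCCn1c(=O)[nH]c2c(ncn2C2O[C@H](CO)[C@@H](O)[C@H]2O)c1=N`: > 100 mg/kg

Both entries are limits of the assay and not numbers. Compound 2 has only the limit > 100 mg/kg, so its place in the series cannot be given as a number. Among the measured compounds shown here, the series so far rests on (the limit of > 100 mg/kg in this assay, at which 2 of the 2 values shown sit).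

The next change leads to compound 3 `N=c1c2ncn(C3O[C@H](CO)[C@@H](O)[C@H]3O)c2[nH]c(=O)n1-c1ccccc1`, with phenyl in place of butyl on an aromatic nitrogen. For the measured compounds named here, the only measured step that bears on this change is a step that the two limits leave unreadable from compound 1 to compound 2. It concerns the chain on that same nitrogen, but it offers no size or direction to carry over. Going by the values given here, no step of definite size or direction can therefore be derived for this assay, and the expectation is that compound 3 may again be reported only as a limit. The expected step, a step that the limit leaves unreadable from compound 2 to compound 3, is a loose estimate. For compound 3 the estimated value is 150 mg/kg, with an expected range of 60 mg/kg to 400 mg/kg.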

Compound 3, dose for half-maximal effect: > 100 mg/kg
Compound 3 ended at the assay's limit (the forecaster's own chance of this, stated with the estimate: 70%); the middle value is on the limit's open side.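

No new step can be read for compound 3 against compound 1 or compound 2, as all three entries are limits and not numbers: the limit of > 100 mg/kg in this assay, at which 3 of the 3 values shown sit.

In this assay the compounds shown leave open whether ethyl, butyl and phenyl on the aromatic nitrogen differ at all, and what dose of any of the three gives a half-maximal effect.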